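The source may hold more compounds than are shown below. What is called first, only, known or untested is meant among the compounds shown, and "the series" means these compounds.

In an ADME assay on HEK293 cells (Homo sapiens) for cytotoxicity, read by resazurin assay, with a stated time of 48 h (on this read-out higher numbers stand for lower toxicity in this test and lower numbers for higher toxicity in this test), compound 1 `COc1ccc(S(=O)(=O)Nc2ccc3oc(-c4ccc(NC(=O)c5ccc(Cl)s5)cc4)nc3c2)cc1` gives 15000 nM and compound 2 `COc1ccc(S(=O)(=O)Nc2ccc3oc(-c4ccc(NS(=O)(=O)c5cc(Br)ccc5OC)cc4)nc3c2)cc1` gives 18000 nM, so compound 2 stands level with compound 1 within the scatter. For the measured compounds named here, the one measured step, a 1.2-fold higher number from compound 1 to compound 2 (0.08 log units; within the scatter), exchanged one group on a nitrogen on an aromatic ring for another. Compound 3 `COc1ccc(S(=O)(=O)Nc2ccc3oc(-c4ccc(NC(=O)C5CCN(C(C)=O)CC5)cc4)nc3c2)cc1` changes that same place: (1-acetylpiperidin-4-yl)carbonyl in place of (5-bromo-2-methoxyphenyl)sulfonyl on a nitrogen on an aromatic ring. Resting on compound 2 at 18000 nM and on a 1.2-fold higher number from compound 1 to compound 2 (0.08 log units; within the scatter), no step beyond the scatter is expected in this assay. The expected step is a 1.1-fold higher number from compound 2 to compound 3 (0.05 log units; within the scatter). The value estimated for compound 3 is 20000 nM, with a range of 9000 nM to 45000 nM.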

Compound 3, half-maximal cytotoxic concentration: 34000 nM
Estimate against measurement, compound 3: 1.7-fold (0.23 log units) below; low and high end bracket the measured number.
By their numbers in this assay, from the lowest: compounds 1, 2 and 3 (each within the scatter of the next, the first and the last beyond it).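

Replacing the (5-bromo-2-methoxyphenyl)sulfonyl group with (1-acetylpiperidin-4-yl)carbonyl leaves the number within the scatter (a 1.9-fold higher number from compound 2 to compound 3 (0.28 log units; within the scatter)). For the compounds shown here, on the same carbonyl carbon, however, 1-acetylpiperidin-4-yl in place of 5-chlorothiophen-2-yl gives the first step at this position beyond the scatter, a modest one towards lower toxicity in this test (a 2.3-fold higher number from compound 1 to compound 3 (0.36 log units; beyond the scatter)). No measured evidence accounts for this step. The compounds shown leave open whether a piperidine with a free amine in place of the acetylated nitrogen would hold this number. They also leave open how a carboxylic acid on that ring would read.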